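Chloro to Iodo in Two Matched Pairs

A few compounds are considered here, and "the series" means these few. Any claim that something is new, unique, unknown or untested is made for them only; others in the source may bear on it.

Compound 1 `NC(=O)c1cc(CCl)[nH]n1` and compound 2 `NC(=O)c1cc(CI)[nH]n1` share a core and differ by iodo in place of chloro on a saturated chain carbon bound to an aromatic carbon. In a functional assay on HeLa cells (Homo sapiens) (on this read-out lower numbers stand for an effect already at smaller amounts and higher numbers for an effect only at larger amounts of compound), compound 1 gives > 100 ug/mL, which is a limit of the assay and not a number. In this assay compound 2 likewise gives > 100 ug/mL, again a limit. The step that the two limits leave unreadable from compound 1 to compound 2 therefore stays unreadable because of the limit of > 100 ug/mL in this assay, at which 2 of the 3 values shown sit.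

Compound 3 `CC(=O)OC[C@H]1O[C@@H](n2nc(CCl)cc2C(N)=O)[C@H](OC(C)=O)[C@@H]1OC(C)=O` carries the chloromethyl group on a larger core; how its core differs from that of compound 1 is not broken down here. In this assay, going by the values given here, compound 3 gives 26 ug/mL, the only number among the three measured values.

Compound 4 `CC(=O)OC[C@H]1O[C@@H](n2nc(CI)cc2C(N)=O)[C@H](OC(C)=O)[C@@H]1OC(C)=O` is not yet measured and differs from compound 3 by iodo in place of chloro on a saturated chain carbon bound to an aromatic carbon, the same change as between compound 1 and compound 2. Since that earlier step could not be read, the expectation for compound 4 rests on compound 3 with 26 ug/mL and on the small size of the change, and the step of a 1.3-fold lower number from compound 3 to compound 4 (0.11 log units; within the scatter) is expected to be small. Compound 4 is thus estimated at 20 ug/mL, between 7 ug/mL and 60 ug/mL.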

Compound 4, concentration for half-maximal effect: 1.5 ug/mL
Beside the measured number, compound 4's estimate is 13-fold (1.12 log units) above it; the whole stated range lies above it.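

In this assay the change from chloromethyl to iodomethyl gives a 17-fold lower number from compound 3 to compound 4 (1.24 log units; beyond the scatter) on the core shared by these two compounds, a large step on that core. The matching step on the core of compound 1 cannot be read, because both of its values are limits of the assay and not numbers: the limit of > 100 ug/mL in this assay, at which 2 of the 4 values shown sit. The series therefore shows a large effect of this change on one core only; it does not show that the effect carries over from one core to the other, and a single readable pair sets no pattern and gives no reason for the size of the step.

The compounds shown leave open whether bromomethyl in place of chloromethyl on the same core would fall in line with this step. Also open, on these data alone, is how an aminomethyl group at that place would read, and whether the step would survive with free hydroxyl groups in place of the acetate groups.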